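Urea to Benzamide: a Large Loss Expected

This account rests on a few compounds, and the source may have more. Where it says the series, first, only, none or still open, it means among the compounds named here.

Of the compounds shown here, three built on one shared core have been tested in a functional assay on PC-3 cells (Homo sapiens) for inhibition, read by sulforhodamine B assay, with a stated time of 48 h; on this read-out higher numbers stand for weaker inhibition of growth and lower numbers for stronger inhibition of growth. Compound 3 `COc1cc(-c2nn(-c3cccc(NC(=O)Nc4ccc(Cl)c(C(F)(F)F)c4)c3)cc2-c2ccncc2)ccc1Cl` gives 2450 nM, the lower of the two numbers read; compound 1 `COc1cc(-c2nn(-c3cccc(NC(=O)Nc4ccc(Cl)c(Cl)c4)c3)cc2-c2ccncc2)ccc1Cl` gives 2830 nM, and the step of a 1.2-fold lower number from compound 1 to compound 3 (0.06 log units; within the scatter) does not separate them. Compound 2 `COc1cc(-c2nn(-c3cccc(NC(=O)c4ccc(Cl)c(C(F)(F)F)c4)c3)cc2-c2ccncc2)ccc1Cl` returns only a limit of the assay, > 32500 nM. The step of an at least 13-fold lower number from compound 2 to compound 3 (1.12 log units; beyond the scatter), and likewise an at least 11-fold higher number from compound 1 to compound 2 (1.06 log units; beyond the scatter), shows that trading the urea for a benzamide on the carbonyl carbon costs a great deal of growth inhibition.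

Compound 4 `COc1cc(-c2nn(-c3cccc(NC(=O)c4ccccc4)c3)cc2-c2ccncc2)ccc1Cl` has not yet been measured. It differs from compound 3 by phenyl in place of (4-chloro-3-(trifluoromethyl)phenyl)amino on a carbonyl carbon. This change removes the amino link that distinguishes compound 3 from compound 2 and also strips the ring of its chloro and trifluoromethyl groups. The step of a 1.2-fold lower number from compound 1 to compound 3 (0.06 log units; within the scatter) suggests the ring substituents count for little, whereas an at least 13-fold lower number from compound 2 to compound 3 (1.12 log units; beyond the scatter) bears directly on the loss of the amino link. A large upward step in this assay is therefore expected, about a 16-fold higher number from compound 3 to compound 4 (1.21 log units; beyond the scatter). Compound 4 is estimated at 40000 nM, within a range of 12000 nM to 130000 nM, and it may well come back only as the limit of > 32500 nM in this assay, at which 1 of the 3 values shown sits.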

Compound 4, concentration for total growth inhibition: > 100000 nM
Compound 4 was reported as a limit; the forecaster's own chance of this, stated with the estimate: 65%; middle value at least 2.5-fold (0.39 log units) from the limit.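

In this assay, placing phenyl on the carbonyl carbon gives an at least 40-fold higher number from compound 3 to compound 4 (1.61 log units; beyond the scatter), and the urea with the (3,4-dichlorophenyl)amino group shows the same picture, with an at least 35-fold higher number from compound 1 to compound 4 (1.54 log units; beyond the scatter). Compound 4 is reported only as a limit of the assay, not as a number: the limit of > 100000 nM in this assay, at which 1 of the 4 values shown sits. The earlier compounds had shown the loss only for a benzamide that kept its chloro and trifluoromethyl groups, whereas this result shows that a benzamide with a bare phenyl at this position also gives no readable growth inhibition and does not come near either urea.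

The step between compound 2 and compound 4 cannot be read, as compound 2 also stands only as a limit: the limit of > 32500 nM in this assay, at which 1 of the 4 values shown sits. On these data alone, it therefore stays open whether the chloro and trifluoromethyl groups matter at all on a benzamide, whether a urea with a plain phenylamino group would keep the inhibition of compound 1 and compound 3, and whether a benzylamino group or a morpholine on the same carbonyl carbon would do so.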